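The source may hold more compounds than are shown below. What is called first, only, known or untested is meant among the compounds shown, and "the series" means these compounds.

Compound 1, `COc1cc2cc(Oc3ccc(NC(=O)Nc4ccc(C)cc4)cc3)c(C)nc2cc1OC`: 107%
Compound 2, `COc1cc2cc(Oc3ccc(NC(=O)Nc4ccc(C(F)(F)F)cc4)cc3)c(C)nc2cc1OC`: 64.1%
Compound 3, `COc1cc2cc(Oc3ccc(NC(=O)Nc4cccc(C(F)(F)F)c4)cc3)c(C)nc2cc1OC`: 6.98%

These three compounds share one core and differ only in the aryl group carried on the urea nitrogen. In a functional assay on NCI/ADR-RES cells (Homo sapiens) for inhibition, read by sulforhodamine B assay, with a stated time of 48 h, tested at 10 uM (on this read-out lower numbers stand for a stronger effect and higher numbers for a weaker effect at the one concentration tested), compound 2 gives 64.1%, the second highest of the three numbers, so its effect is middling: compound 1 sits higher and compound 3 sits well lower, both beyond the scatter.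

Compound 4, `COc1cc2cc(Oc3ccc(NC(=O)Nc4ccc(Cl)c(C(F)(F)F)c4)cc3)c(C)nc2cc1OC`, has not been measured yet. It differs from compound 2 in one place: 4-chloro-3-(trifluoromethyl)phenyl in place of 4-(trifluoromethyl)phenyl on an amide-type nitrogen. For the measured compounds named here, two measured steps bear on this change. The first is a number 42.9 percentage points lower from compound 1 to compound 2 (beyond the scatter), where trifluoromethyl replaced methyl on an aromatic carbon, a large fall. The second is a number 57.1 percentage points lower from compound 2 to compound 3 (beyond the scatter), where 3-(trifluoromethyl)phenyl replaced 4-(trifluoromethyl)phenyl, an even larger fall that brought compound 3 down to 6.98%. Compound 4 carries the 4-chloro-3-(trifluoromethyl)phenyl group, which holds a trifluoromethyl together with a chlorine, so a large downward step is expected, though whether it matches compound 3 is uncertain with only three points in hand. For compound 4 the expected step is a number 44.1 percentage points lower from compound 2 to compound 4 (beyond the scatter), giving an estimated value of 20%, most likely between 3% and 55%.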

Compound 4, a percentage reported as activity, at one concentration (the size of the read-out at that concentration, not a potency): 2.01%
Compound 4: middle estimate off by 18 percentage points, on the high side; the measured number lies below the stated range.
By their numbers in this assay, from the lowest: compounds 4 and 3 (each within the scatter of the next); then compound 2; then compound 1.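

In this assay, the step from the 3-(trifluoromethyl)phenyl group to the 4-chloro-3-(trifluoromethyl)phenyl group is a number 5 percentage points lower from compound 3 to compound 4 (within the scatter), so these two compounds cannot be told apart and the added chloro shows no measurable effect of its own on this read-out. Measured against the two weaker compounds, the same group gives a number 62.1 percentage points lower from compound 2 to compound 4 (beyond the scatter) and a number 105 percentage points lower from compound 1 to compound 4 (beyond the scatter), and both steps are large. For the compounds shown here, the earlier compounds carried only one group on the aryl ring, and compound 4 adds what they could not show: the strong effect seen with compound 3 survives when a chloro is added to that ring, so this position tolerates at least this one extra atom without losing the effect.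

Going by these compounds, a single concentration also says nothing about potency, and with compound 3 and compound 4 so close, it remains open whether a larger or quite different group on this ring, such as an amine, a carboxylic acid or a longer alkyl chain, would keep the effect. Nothing measured here explains why these aryl groups differ so widely in this assay.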